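This account rests on a few compounds, and the source may have more. Where it says the series, first, only, none or still open, it means among the compounds named here.

Measured in a functional assay on PC-3 cells (Homo sapiens) for inhibition, read by sulforhodamine B assay, with a stated time of 48 h, tested at 50 uM; on this read-out lower numbers stand for less inhibition of growth and higher numbers for more inhibition of growth at the one concentration tested:
Compound 1 `COc1ccc(/C=C/C(=O)/C=C/c2ccc(OCc3cn(CCCCOc4cc(=O)oc5ccccc45)nn3)c(OC)c2)cc1OC`: "not active" (no number reported)
Compound 2 `COc1ccc(/C=C/C(=O)/C=C/c2ccc(OCc3cn(CCOc4cc(=O)oc5ccccc45)nn3)c(OC)c2)cc1OC`: 19%
Compound 3 `COc1cc(/C=C/C(=O)/C=C/c2ccco2)ccc1OCc1cn(CCOc2cc(=O)oc3ccccc23)nn1`: 14%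

Compound 1 has no number, so the step from it starts without a measured value. Compound 4 `COc1cc(/C=C/C(=O)/C=C/c2cccs2)ccc1OCc1cn(CCCCOc2cc(=O)oc3ccccc23)nn1` keeps the rest of compound 1 but carries thiophen-2-yl in place of 3,4-dimethoxyphenyl on a double-bonded chain carbon bound to a double-bonded chain carbon. For the measured compounds named here, no measured pair makes exactly this change. The nearest pair has furan-2-yl entering at the same place and shows a number 5 percentage points lower from compound 2 to compound 3 (within the scatter). That pair has a different linking chain from compound 1, so it is only a loose guide. On this evidence, no step beyond the scatter is expected in this assay, and compound 4 is expected to stay weak. A report without a number, as for compound 1, is about as likely as a measured result. If a number is reported, the expected value for compound 4 is 10%, with an estimated range of 0% to 22%.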

Compound 4, percent growth inhibition at one concentration: "not active" (no number reported)
No number was reported for compound 4, so the estimate cannot be set against anything.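

In this assay compound 1 gives "not active" (no number reported) and compound 4 gives "not active" (no number reported) so no step can be read between them, and no evidence at hand bears on this result. As far as these compounds go, whether thiophen-2-yl in place of 3,4-dimethoxyphenyl changes growth inhibition at all stays open.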